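This account rests on a few compounds, and the source may have more. Where it says the series, first, only, none or still open, it means among the compounds named here.

In a functional assay on EC9706 cells (Homo sapiens) for cytotoxicity, read by MTT assay, with a stated time of 72 h (on this read-out higher numbers stand for weaker inhibition and lower numbers for stronger inhibition), compound 1 `NC(=O)N1CCN(C(=S)SCc2cn(Cc3ccccc3F)nn2)CC1` gives 43100 nM. Compound 2 `CCNC(=O)N1CCN(C(=S)SCc2cn(Cc3ccccc3F)nn2)CC1` differs from it by ethyl in place of hydrogen on an amide-type nitrogen and in this assay compound 2 gives 23700 nM; the step is a 1.8-fold lower number from compound 1 to compound 2 (0.26 log units; within the scatter). Compound 3 `COc1ccc(Cn2cc(CSC(=S)N3CCN(C(N)=O)CC3)nn2)cc1` carries a different core, the difference being (4-methoxyphenyl in place of 2-fluorophenyl on a saturated chain carbon bound to an aromatic nitrogen). In this assay compound 3 reaches only a limit of the assay, > 128000 nM. The step from the first core to the second is therefore bounded rather than fixed, an at least 2.9-fold higher number from compound 1 to compound 3 (0.47 log units; beyond the scatter), because its far end is set by the limit of > 128000 nM in this assay, at which 1 of the 3 values shown sits.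

Compound 4 `CCNC(=O)N1CCN(C(=S)SCc2cn(Cc3ccc(OC)cc3)nn2)CC1` has not yet been measured in this assay. It differs from compound 3 by ethyl in place of hydrogen on an amide-type nitrogen. This is the same change that turns compound 1 into compound 2, now made on the core of compound 3; the place is the same in both cases, an amide-type nitrogen whose other neighbour is a carbonyl carbon, so the change is the same kind as before and not merely similar. Given that the earlier step of a 1.8-fold lower number from compound 1 to compound 2 (0.26 log units; within the scatter) lay within the scatter, the expected step here is an at least 1.1-fold lower number from compound 3 to compound 4 (0.06 log units; that floor lies within the scatter), resting on that single earlier pair alone. Compound 3 stands at a limit, so the estimate carries a real chance that compound 4 also yields only a limit. The expected value for compound 4 in this assay is 110000 nM, with a range from 50000 nM to 250000 nM.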

Compound 4, half-maximal inhibitory concentration: > 128000 nM
Compound 4: only a limit was reported; the forecaster's own chance of this, stated with the estimate: 55%; middle value at least 1.1-fold (0.06 log units) from the limit.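

In this assay compound 4 gives > 128000 nM, which is a limit of the assay and not a number. On the core that carries the ethylcarbamoyl group, 4-methoxyphenyl in place of 2-fluorophenyl gives an at least 5.4-fold higher number from compound 2 to compound 4 (0.73 log units; beyond the scatter), so this change moves the number the same way on both cores, though the true size of neither step is known: the same change on two cores in this assay, an at least 2.9-fold higher number (0.47 log units; beyond the scatter) from compound 1 to compound 3 and an at least 5.4-fold higher number (0.73 log units; beyond the scatter) from compound 2 to compound 4; the limit leaves it open whether they differ. The steps from compound 3 to compound 4 and for ethyl in place of hydrogen on the 4-methoxyphenyl core cannot be read, so this series does not show whether that change carries over from the core of compound 1, and the two limits hide any difference because both compounds stop at the same bound: the limit of > 128000 nM in this assay, at which 2 of the 4 values shown sit.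

As far as these compounds go, how a plain phenyl group would stand on either core remains open, so the step cannot yet be assigned to the loss of the fluorine or to the arrival of the methoxy group. Also open, from the compounds shown here alone, is what a longer chain such as butyl, or an amine-bearing chain, would do on the amide-type nitrogen of the 2-fluorophenyl core, where the values can still be read.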